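The compounds below may be only part of what the source reports. "The series", "measured", "known", "first", "only" and "open" are said of these compounds alone.

Measured in a functional assay on MDA-MB-231 cells (Homo sapiens) for antiproliferative activity, read by CCK-8 assay, with a stated time of 48 h; on this read-out lower numbers stand for stronger inhibition and higher numbers for weaker inhibition:
- compound 1 `O=C(/C=C/CNCCOc1ccc(Oc2c(-c3ccc(F)cc3)sc3cc(O)ccc23)cc1)N1CCCC1`: > 50000 nM
- compound 2 `CNC(=O)/C=C/CN1CC(Oc2ccc(Oc3c(-c4ccc(F)cc4)sc4cc(O)ccc34)cc2)C1`: > 50000 nM

Compound 2 gives > 50000 nM, which is a limit of the assay and not a number. Compound 1 gives > 50000 nM, also a limit. Among the measured compounds shown here, no measured compound has a numeric value so far: the limit of > 50000 nM in this assay, at which 2 of the 2 values shown sit.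

Compound 3 `C=CC(=O)NCCOc1ccc(Oc2c(-c3ccc(F)cc3)sc3cc(O)ccc23)cc1` carries 2-((vinylcarbonyl)amino)ethyl in place of 1-(3-(methylcarbamoyl)prop-2-en-1-yl)azetidin-3-yl on an oxygen on an aromatic ring. For the measured compounds named here, no measured step is available to scale this change. Weak activity in this assay is still expected, given that both measured compounds sit at the same limit: the limit of > 50000 nM in this assay, at which 2 of the 2 values shown sit. At most a modest gain in inhibition is expected, and the estimated step is an at least 1.4-fold lower number from compound 2 to compound 3 (0.15 log units; that floor lies within the scatter). For compound 3 the estimate is 35000 nM, with an expected range of 10000 nM to 50000 nM.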

Compound 3, half-maximal inhibitory concentration: > 50000 nM
Compound 3: a limit, no number (the forecaster's own chance of this, stated with the estimate: 65%); middle value at least 1.4-fold (0.15 log units) away from the limit.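

No step can be read from compound 1 or compound 2 to compound 3, because all three compounds end at a limit and not at a number: the limit of > 50000 nM in this assay, at which 3 of the 3 values shown sit.

The compounds shown leave open whether either change shifts inhibition at all.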